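Trifluoromethyl for Chloro on the Shared Core

The source may report more compounds than this note shows. Statements on the series, on what has been measured and on what is new or still open speak of the compounds shown alone.

Three compounds with the same core and the same three-carbon chain to a ring nitrogen have been measured in a functional assay on MCF7 cells (Homo sapiens) for antiproliferative activity, read by sulforhodamine B assay, with a stated time of 48 h; a lower number here means a stronger inhibitor of growth, a higher number a weaker inhibitor of growth. Compound 1 `CCN(CC)CCCNc1ccnc2cc(Cl)ccc12` gives 17900 nM. Compound 2 `Clc1ccc2c(NCCCN3CCCCC3)ccnc2c1` gives 17700 nM, and compound 3 `CN1CCN(CCCNc2ccnc3cc(Cl)ccc23)CC1` gives 17100 nM. Compound 1 carries the highest of the three numbers, but the steps of a 1.0-fold lower number from compound 1 to compound 2 (0.00 log units; within the scatter) and a 1.0-fold lower number from compound 1 to compound 3 (0.02 log units; within the scatter) both fall within the scatter, as does a 1.0-fold lower number from compound 2 to compound 3 (0.01 log units; within the scatter), so the three amines on the chain end cannot be told apart here.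

Compound 4 `CCN(CC)CCCNc1ccnc2cc(C(F)(F)F)ccc12` differs from compound 1 in another place: trifluoromethyl in place of chloro on an aromatic carbon. Within the data shown here, no measured step touches that ring carbon; every step recorded so far changes only the amine at the far end of the chain, and each of those was within the scatter. Among the measured compounds shown here, there is therefore no direct precedent for the size or direction of the move from chloro to trifluoromethyl on the ring, and the only anchor is the number for compound 1 itself. On that basis the expected step is a 1.2-fold lower number from compound 1 to compound 4 (0.08 log units; within the scatter), without a firm direction. Compound 4 is estimated at 15000 nM in this assay, with a range from 5000 nM to 45000 nM.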

Compound 4, concentration for 50% growth inhibition: 20600 nM
Compound 4: middle estimate off by 1.4-fold (0.14 log units), on the low side; measured number inside the range.
By their numbers in this assay, from the lowest: compounds 3, 2, 1 and 4 (each within the scatter of the next).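

In this assay, among these compounds, the only measured step on the ring, made on an aromatic carbon of the six-membered aromatic ring of carbon only, gives a 1.2-fold higher number from compound 1 to compound 4 (0.06 log units; within the scatter). Trifluoromethyl and chloro therefore cannot be told apart at this position, even though four heavy atoms stand there in place of one. This ring position now joins the far end of the chain, where the amines of compounds 1, 2 and 3 could not be told apart either, and no evidence is available to account for either result.

As far as these compounds go, whether a different group on this aromatic carbon, such as a methoxy group, a nitrile, an amine or a plain hydrogen, would separate from chloro remains open, as does whether trifluoromethyl would behave the same with piperidin-1-yl or 4-methylpiperazin-1-yl at the chain end. The chain itself is common to all four compounds, so the compounds shown also leave open what a longer or shorter chain would do to these numbers.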